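The source may hold more compounds than are shown below. What is called first, only, known or untested is meant among the compounds shown, and "the series" means these compounds.

Measured so far:
compound 1, `CC(C(=O)NCc1ccc(C(F)(F)F)cc1N1CCCCCCC1)c1ccc(NS(C)(=O)=O)c(F)c1`: 2.8 nM
compound 2, `CC(C)CCOc1cc(C(F)(F)F)ccc1CNC(=O)C(C)c1ccc(NS(C)(=O)=O)c(F)c1`: 0.5 nM
compound 3, `CC(C(=O)NCc1ccc(C(F)(F)F)cc1SC1CCCC1)c1ccc(NS(C)(=O)=O)c(F)c1`: 0.3 nM

All three share one core and differ only in the group on the aromatic carbon ortho to the large group. In an assay on CHO cells for antagonist activity at transient receptor potential cation channel subfamily V member 1 (Homo sapiens), read by FLIPR (on this read-out lower numbers stand for stronger inhibition and higher numbers for weaker inhibition), compound 3 gives the lowest of the three numbers; the nearest is compound 2, and their gap, a 1.7-fold lower number from compound 2 to compound 3 (0.22 log units; within the scatter), lies within the scatter, so compound 2 and compound 3 cannot be ordered against each other. Compound 1 stands furthest, with a 9.3-fold lower number from compound 1 to compound 3 (0.97 log units; beyond the scatter) and a 5.6-fold lower number from compound 1 to compound 2 (0.75 log units; beyond the scatter) both beyond the scatter.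

Compound 4, `CC(C(=O)NCc1ccc(C(F)(F)F)cc1-c1ccc(F)c(Cl)c1)c1ccc(NS(C)(=O)=O)c(F)c1`, carries the change (3-chloro-4-fluorophenyl in place of cyclopentylsulfanyl on an aromatic carbon). For the measured compounds named here, no measured step replaces a ring-bearing group by an aromatic ring at this position, so the steps seen only show that this position tolerates groups of varied shape, with an eight-membered ring giving the weakest result. A biaryl group is a larger departure than the swap between compound 2 and compound 3. The expected step is therefore a modest rise, a 2.7-fold higher number from compound 3 to compound 4 (0.43 log units; beyond the scatter), carrying uncertainty in both directions. For compound 4 the estimate in this assay is 0.8 nM, within 0.2 nM to 4 nM.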

Compound 4, inhibition constant: 0.6 nM
Compound 4: middle estimate off by 1.3-fold (0.12 log units), on the high side, and the stated range covers the measured number.
By their numbers in this assay, from the lowest: compounds 3, 2 and 4 (each within the scatter of the next); then compound 1.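

In this assay an aromatic ring now stands at this position, on an aromatic carbon ortho to a large group, and it sits level with the two best non-aromatic groups: a 2.0-fold higher number from compound 3 to compound 4 (0.30 log units; within the scatter) and a 1.2-fold higher number from compound 2 to compound 4 (0.08 log units; within the scatter) both stay within the scatter, so these three compounds cannot be ordered against each other. The eight-membered ring carries as many heavy atoms as 3-chloro-4-fluorophenyl, yet the step here is a 4.7-fold lower number from compound 1 to compound 4 (0.67 log units; beyond the scatter) and so heavy-atom count alone does not separate the two groups at this position. Nothing on hand explains these numbers.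

Open is whether the chlorine and the fluorine of 3-chloro-4-fluorophenyl each contribute, as a plain phenyl is not among the compounds shown. Also open, going by these compounds, is how a group carrying an amine or a carboxylic acid would read at this position.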